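The source may report more compounds than this note shows. Statements on the series, on what has been measured and on what is new or still open speak of the compounds shown alone.

Compound 1 `COc1c(F)cccc1C1CCN(c2ccn3c(CC4CC4)nnc3c2Cl)CC1`, compound 2 `COc1c(F)ccc(F)c1C1CCN(c2ccn3c(CC4CC4)nnc3c2Cl)CC1` and compound 3 `COc1c(F)cccc1C1CCN(c2ccn3c(CC4CC4)nnc3c2C(F)(F)F)CC1` share one core and differ only in the groups hung on it. In an ADME assay on a cell-free system (plasma, Homo sapiens) for protein binding (a higher number here means a larger unbound share of the compound, a lower number a smaller unbound share), compound 3 gives < 0.01, which is a limit of the assay and not a number. Compound 1 gives < 0.01 in this assay, again a limit. Compound 2 gives < 0.01, a limit as well. Because all three values sit at the limit of < 0.01 in this assay, at which 3 of the 3 values shown sit, compound 3 cannot be placed against the other two, and the steps a step that the two limits leave unreadable from compound 1 to compound 2 and a step that the two limits leave unreadable from compound 1 to compound 3 stay unreadable.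

Compound 4 `COc1c(F)ccc(F)c1C1CCN(c2ccn3c(CC4CC4)nnc3c2C(F)(F)F)CC1` has not been measured in this assay. It differs from compound 3 by fluoro in place of hydrogen on an aromatic carbon. Going by the values given here, the only measured step of the same kind, a step that the two limits leave unreadable from compound 1 to compound 2, tells nothing about its size because both of its ends lie at the limit of < 0.01 in this assay, at which 3 of the 3 values shown sit. Among the compounds with values here, no other measured step bears on this change. Compound 4 is therefore expected to remain at the limit, with an estimated step that the limit leaves unreadable from compound 3 to compound 4 that is not expected to go beyond the scatter in either direction. Compound 4 is estimated at 0.005, with a range from 0.002 to 0.012.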

Compound 4, unbound fraction: < 0.01
Compound 4: no number, only a limit; the forecaster's own chance of this, stated with the estimate: 85%; the middle value lies beyond the limit too.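

No new step can be read from compound 4 to compound 2 or compound 3, since the values sit at one limit: the limit of < 0.01 in this assay, at which 4 of the 4 values shown sit. The compounds shown leave open whether fluoro in place of hydrogen, or trifluoromethyl in place of chloro, shifts the unbound fraction at all in this assay.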